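From a Trifluoromethylbenzyl Ether to a Methyl Ether

This account rests on a few compounds, and the source may have more. Where it says the series, first, only, none or still open, it means among the compounds named here.

Compound 1 `COc1ccc(C2Cc3ccccc3C(C3=C(O)OC(C)(c4ccccc4)CC3=O)C2)cc1` and compound 2 `CCC1(c2ccccc2)CC(=O)C(C2CC(c3ccc(OCc4ccc(C(F)(F)F)cc4)cc3)Cc3ccccc32)=C(O)O1` were both examined in a functional assay on XF498 cells (Homo sapiens) for inhibition, with a stated time of 72 h; on this read-out lower numbers stand for stronger inhibition and higher numbers for weaker inhibition. In this assay compound 1 reaches only the limit > 10000 nM. Compound 2 likewise gives only the limit > 10000 nM. Within the data shown here, compound 2 therefore stands at the same limit as the one other value shown, (the limit of > 10000 nM in this assay, at which 2 of the 2 values shown sit), and no numbered value exists for either compound. Compound 3 `CCC1(c2ccccc2)CC(=O)C(C2CC(c3ccc(OC)cc3)Cc3ccccc32)=C(O)O1` has not been measured; it differs from compound 2 by hydrogen in place of 4-(trifluoromethyl)phenyl on a saturated chain carbon bound to an oxygen on an aromatic ring. Among the measured compounds shown here, no measured pair shares this change, so no step can be drawn on. With both known values at the limit, nothing points toward a stronger or weaker result for compound 3, and the expected step that the limit leaves unreadable from compound 2 to compound 3 is one that stays within the scatter. Compound 3 is accordingly estimated at 15000 nM, between 5000 nM and 50000 nM, most likely reported again as a limit.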

Compound 3, half-maximal inhibitory concentration: > 10000 nM
Compound 3 gave a limit, no number (the forecaster's own chance of this, stated with the estimate: 80%); the middle value lies beyond the limit too.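

Compound 3 also gives only a limit in this assay, so no step can be read among compound 1, compound 2 and compound 3: the limit of > 10000 nM in this assay, at which 3 of the 3 values shown sit.

The compounds shown leave open whether any other group in this place would give a numbered value in this assay.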